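Replacing a hydroxyl-bearing chain with a plain branched chain

The source may report more compounds than this note shows. Statements on the series, on what has been measured and on what is new or still open speak of the compounds shown alone.

Measured so far:
compound 1 `Nc1cc(Oc2ccc(NC(=O)Nc3cccc(C(F)(F)F)c3)cc2)ncn1` gives 25 nM
compound 2 `C[C@@H](O)CNc1cc(Oc2ccc(NC(=O)Nc3cccc(C(F)(F)F)c3)cc2)ncn1` gives 63 nM

Both were tested in an assay on isolated protein for inhibition of serine/threonine-protein kinase TNNI3K (Homo sapiens); a higher number here means a weaker inhibitor, a lower number a stronger inhibitor. Compound 2 stands with the highest of the two numbers; its nearest neighbour is compound 1, and the step of a 2.5-fold higher number from compound 1 to compound 2 (0.40 log units; beyond the scatter) is modest but beyond the scatter. Compound 3 `CC(C)CNc1cc(Oc2ccc(NC(=O)Nc3cccc(C(F)(F)F)c3)cc2)ncn1` has not been measured. It differs from compound 2 by isopropyl in place of 1-hydroxyethyl on a saturated chain carbon bound to a nitrogen on an aromatic ring; one bond further out, the whole 2-hydroxypropyl group gives way to isobutyl. Going by the values given here, only the step from compound 1 to compound 2 bears on this, and it concerns adding the whole chain, not exchanging the hydroxyl within it. Nothing measured shows whether the hydroxyl itself matters. Compound 3 is therefore expected to stay close to compound 2, with the step of a 1.1-fold lower number from compound 2 to compound 3 (0.06 log units; within the scatter) not beyond the scatter. The estimate for compound 3 is 55 nM, in the range 15 nM to 200 nM.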

Compound 3, half-maximal inhibitory concentration: 50 nM
For compound 3 the middle estimate is 1.1-fold (0.04 log units) above the measured one; measured number inside the range.
By their numbers in this assay, from the lowest: compounds 1, 3 and 2 (each within the scatter of the next, the first and the last beyond it).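

In this assay, isopropyl in place of 1-hydroxyethyl gives a 1.3-fold lower number from compound 2 to compound 3 (0.10 log units; within the scatter) and so the two numbers cannot be told apart: at this position, the hydroxyl and the defined stereocentre can go without a measurable difference. The parent comparison also sharpens, since a 2.0-fold higher number from compound 1 to compound 3 (0.30 log units; within the scatter) stands beside a 2.5-fold higher number from compound 1 to compound 2 (0.40 log units; beyond the scatter) as the step for the hydroxyl-bearing chain, yet this contrast should not be over-read while compound 2 and compound 3 themselves lie within the scatter. Nothing available gives a reason for these results.

As far as these compounds go, whether a longer chain, or a chain ending in an amine or a carboxylic acid, would fit this position equally well remains open. So does the behaviour of the mirror-image 2-hydroxypropyl chain.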